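Fluoro for methoxy on the aryl tail: stability in microsomes

A few compounds are considered here, and "the series" means these few. Any claim that something is new, unique, unknown or untested is made for them only; others in the source may bear on it.

Compound 3 `COc1cccc(CC[C@H](O)C[C@@H](O)c2cc(-c3ccccc3)on2)c1` gives in an ADME assay on microsomes from liver (Homo sapiens) for metabolic stability, read by LC-MS, using NADPH, with stated times of 5 min and 30 min, tested at 1 uM (a lower number here means that less of the compound is left, a higher number that more of the compound is left), only a limit, < 20%; this is one of the values that sit at the limit of < 20% in this assay, at which 1 of the 3 values shown sits. Compound 1 `COc1ccc(CC[C@H](O)C[C@H](O)c2cc(-c3ccccc3)on2)cc1` gives 33% in this assay, and compound 2 `O[C@@H](CCc1ccc(F)cc1)C[C@H](O)c1cc(-c2ccccc2)on1` gives 84%. Among the measured compounds shown here, the one measured step, a number 51 percentage points higher from compound 1 to compound 2 (beyond the scatter), is the same kind of exchange of fluoro for methoxy. Compound 4 `O[C@@H](CCc1ccc(F)cc1)C[C@@H](O)c1cc(-c2ccccc2)on1` differs from compound 3 by 4-fluorophenyl in place of 3-methoxyphenyl on a saturated chain carbon, three bonds along the chain from an oxygen on a saturated carbon. On that basis a large step upward is expected, well beyond the scatter, though compound 3 stands only at a limit. For compound 4 the expected value in this assay is 60%, within 35% to 85%. This estimate corresponds to a number at least 40 percentage points higher from compound 3 to compound 4 (beyond the scatter).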

Compound 4, percent of the compound remaining in the Homo sapiens assay: 73%
The estimate for compound 4 lay 13 percentage points below the measured number, within the range that was stated.
By their numbers in the Homo sapiens assay, from the lowest: compound 1; then compound 4; then compound 2. At a limit, below all of these: compound 3.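

In the Homo sapiens assay the exchange also holds on the other configuration and with 3-methoxyphenyl leaving, a number at least 53 percentage points higher from compound 3 to compound 4 (beyond the scatter), a bound only, with compound 3 standing at a limit: the limit of < 20% in the Homo sapiens assay, at which 1 of the 4 values shown sits.
In the Homo sapiens assay configuration at one chain carbon also registers, a number 11 percentage points lower from compound 2 to compound 4 (beyond the scatter), a modest step: the fact that compounds 2 and 4 differ only in the configuration as drawn
In a physicochemical assay for solubility, in phosphate buffer, measured as kinetic solubility, at pH 7.4 (on this read-out higher numbers stand for higher solubility and lower numbers for lower solubility), compound 3 gives 25000 nM and compound 4 gives 25000 nM, so the exchange leaves that read-out level.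

Open, going by these compounds, is whether a chloro group or a nitrile in place of the fluoro keeps the stability of compound 4 in the Homo sapiens assay. Also open, on these data alone, is how much the methoxy position alone contributes, since 3-methoxyphenyl and 4-methoxyphenyl appear here only on different configurations.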